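The compounds below may be only part of what the source reports. "The series", "measured", "known", "first", "only" and "open" are said of these compounds alone.

Measured so far in a functional assay on HOP-92 cells (Homo sapiens) for inhibition, read by sulforhodamine B assay, with a stated time of 48 h (a higher number here means that more compound is tolerated, a lower number that less compound is tolerated), each entry a limit of the assay and not a number:
Compound 1 `COc1cc(-c2nn(-c3cccc(NC(=O)c4cccc(C(F)(F)F)c4)c3)cc2-c2ccncc2)ccc1Cl` gives > 50000 nM as a limit
Compound 2 `COc1cc(-c2nn(-c3cccc(NC(=O)Nc4ccc(Cl)c(Cl)c4)c3)cc2-c2ccncc2)ccc1Cl` gives > 50000 nM as a limit
Compound 3 `O=C(Nc1cccc(-n2cc(-c3ccncc3)c(-c3ccc(Cl)c(O)c3)n2)c1)Nc1ccc(Cl)c(Cl)c1` gives > 32500 nM as a limit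

Compound 2 has no number here, only the limit > 50000 nM as its entry. The record of the series is no firmer: the limit of > 50000 nM in this assay, at which 2 of the 3 values shown sit, and the limit of > 32500 nM in this assay, at which 1 of the 3 values shown sits, make up all of it.

Compound 4 (`COc1cc(-c2nn(-c3cccc(NC(=O)Nc4ccc(Cl)c(C(F)(F)F)c4)c3)cc2-c2ccncc2)ccc1Cl`) differs from compound 2 in one place, with trifluoromethyl in place of chloro on an aromatic carbon, ortho to a chloro group and meta to a large group (trifluoromethyl in place of chloro on an aromatic carbon), so that 3,4-dichlorophenyl becomes 4-chloro-3-(trifluoromethyl)phenyl.

The measured steps that bear on this are a step that the two limits leave unreadable from compound 1 to compound 2 and a step that the two limits leave unreadable from compound 2 to compound 3 and neither gives a size. Compound 1 carries 3-(trifluoromethyl)phenyl and shows the limit > 50000 nM as its entry. Within the data shown here, no size of step can be carried over, so no change beyond the scatter is expected, and no direction is claimed. The expected step is an at least 1.1-fold lower number from compound 2 to compound 4 (0.04 log units; that floor lies within the scatter) in this assay on this reading. For compound 4 the estimated value is 45000 nM with an expected range from 20000 nM to 50000 nM and a report as a limit is the likeliest outcome.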

Compound 4, concentration lethal to 50% of the cells: > 32500 nM
Compound 4: only a limit was reported; the forecaster's own chance of this, stated with the estimate: 70%; the middle value is on the limit's open side.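

In this assay compound 4 gives > 32500 nM, a limit of the assay and not a number. The steps from compound 2 and from compound 1 to compound 4 cannot be read. The compounds shown leave open whether trifluoromethyl in place of chloro changes the read-out at all.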